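A few compounds are considered here, and "the series" means these few. Any claim that something is new, unique, unknown or untested is made for them only; others in the source may bear on it.

In a functional assay on HeLa cells (Homo sapiens) for inhibition, read by sulforhodamine B assay (a lower number here means a stronger inhibitor, a higher number a weaker inhibitor), compound 1 `CCc1ccc(NC2=CC(=O)c3c(nc4n3[C@H]3OC[C@@H](O)[C@H]3OC4)C2=O)cc1` gives 6510 nM and compound 2 `Cc1ccc(NC2=CC(=O)c3c(nc4n3[C@H]3OC[C@@H](O)[C@H]3OC4)C2=O)cc1` gives 6590 nM on the shared core. Compound 3 `Cc1ccc(NC2=CC(=O)c3c(nc4n3[C@H]3OC[C@@H](O)[C@H]3OC4)C2=O)cc1C` gives 4320 nM and so stands level with both, as a 1.5-fold lower number from compound 1 to compound 3 (0.18 log units; within the scatter) and a 1.5-fold lower number from compound 2 to compound 3 (0.18 log units; within the scatter) show, while a 1.0-fold higher number from compound 1 to compound 2 (0.01 log units; within the scatter) is equally small. Compound 4 `O=C1C(N2CCC2)=CC(=O)c2c1nc1n2[C@H]2OC[C@@H](O)[C@H]2OC1` differs by azetidin-1-yl in place of (3,4-dimethylphenyl)amino on a double-bonded ring carbon in one place, with azetidin-1-yl in place of (3,4-dimethylphenyl)amino on a double-bonded ring carbon. The measured steps only alter methyl or ethyl groups on the phenyl ring, so they guide this larger exchange weakly. No step beyond the scatter is expected in this assay though confidence is low. From the compounds shown here alone, the estimated step is a 1.1-fold lower number from compound 3 to compound 4 (0.03 log units; within the scatter) and its direction stays open. Compound 4 is expected at 4000 nM with a range from 1000 nM to 15000 nM in this estimate.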

Compound 4, half-maximal inhibitory concentration: > 16000 nM
Compound 4: no number, only a limit; the forecaster's own chance of this, stated with the estimate: 10%; at least 4.0-fold (0.60 log units) between middle value and limit.
By their numbers in this assay, from the lowest: compounds 3, 1 and 2 (each within the scatter of the next). At a limit, above all of these: compound 4.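

In this assay compound 4 gives no number, only a limit: the limit of > 16000 nM in this assay, at which 1 of the 4 values shown sits.

Methyl and ethyl changes on the phenyl ring stayed within the scatter, but this exchange on the double-bonded ring carbon does not, with an at least 3.7-fold higher number from compound 3 to compound 4 (0.56 log units; beyond the scatter), an at least 2.4-fold higher number from compound 2 to compound 4 (0.38 log units; beyond the scatter) and an at least 2.4-fold higher number from compound 1 to compound 4 (0.39 log units; beyond the scatter). Among these compounds, this position therefore responds to replacing the whole arylamino group, not to the small ring substituents.

Azetidin-1-yl removes both the aromatic ring and the amine hydrogen at once, and the compounds shown leave open which loss counts. Cyclohexylamino, which keeps that hydrogen, or methyl(phenyl)amino, which keeps the ring, would separate the two.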